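Losing the Amino Group on Two Related Cores

The source may report more compounds than this note shows. Statements on the series, on what has been measured and on what is new or still open speak of the compounds shown alone.

Compound 1 `Nc1ccnc2ccc(C#Cc3c(F)cccc3F)cc12` gives 66.2% in a functional assay on LS174T cells (Homo sapiens) for inhibition, with a stated time of 4 days, tested at 1 uM; on this read-out lower numbers stand for a weaker effect and higher numbers for a stronger effect at the one concentration tested. Compound 3 `Fc1cccc(F)c1C#Cc1ccc2ncccc2c1` differs from it by one change, (hydrogen in place of amino on an aromatic carbon), and compound 3 gives 11% in this assay, so the step of a number 55.2 percentage points lower from compound 1 to compound 3 (beyond the scatter) is a large one. Compound 2 `Nc1ccnc2cc(C#Cc3c(F)cccc3F)ccc12` has the same atoms as compound 1 joined differently; how the two cores differ is not broken down here. In this assay compound 2 gives 23.6%. Compound 4 `Fc1cccc(F)c1C#Cc1ccc2cccnc2c1` has not yet been measured; it differs from compound 2 by the same change at the same place, (hydrogen in place of amino on an aromatic carbon). Because the measured step of a number 55.2 percentage points lower from compound 1 to compound 3 (beyond the scatter) was large, the same change is expected to yield a step of a number 18.6 percentage points lower from compound 2 to compound 4 (beyond the scatter), limited by the little room left beneath compound 2. Compound 4 is therefore estimated at 5%, between -10% and 20%.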

Compound 4, a percentage reported as inhibition, at one concentration (the size of the read-out at that concentration, not a potency): 90.7%
Beside the measured number, compound 4's estimate is 85.7 percentage points below it; the whole stated range lies below it.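

In this assay, hydrogen in place of amino on an aromatic carbon gives a number 67.1 percentage points higher from compound 2 to compound 4 (beyond the scatter). Set beside the earlier step, the same change moves the read-out in opposite directions on the two cores: the same change on two cores in this assay, a number 55.2 percentage points lower (beyond the scatter) from compound 1 to compound 3 and a number 67.1 percentage points higher (beyond the scatter) from compound 2 to compound 4, 122.3 percentage points apart, beyond the scatter of two such steps. This shows that, in this series, the direction of the step on one core does not carry over to the other, but it does not show why, and two pairs give no rule for any further core.

Every pair shown swaps amino for hydrogen only, so it stays open how a methylamino or hydroxyl group at the same place would read on either core. On these data alone, whether the two cores still part with chloro groups in place of the fluoro groups also stays open.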